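The compounds below may be only part of what the source reports. "The series", "measured", "known", "first", "only" and "open" are said of these compounds alone.

Measured compounds:
compound 1, `COc1cccc(S(=O)(=O)/C=C/c2ccccn2)c1`: 2170 nM
compound 2, `COc1cccc(S(=O)(=O)/C=C/c2ncccc2F)c1`: 444 nM
compound 3, `COc1ccc(S(=O)(=O)/C=C/c2ccccn2)cc1`: > 10000 nM

All values come from an assay on U2OS cells for activation of nuclear factor erythroid 2-related factor 2 (Homo sapiens), read by chemiluminescence, with a stated time of 6 h; on this read-out lower numbers stand for an effect already at smaller amounts and higher numbers for an effect only at larger amounts of compound. In this assay compound 1 gives 2170 nM and compound 2 gives 444 nM. Compound 2 carries the change (fluoro in place of hydrogen on an aromatic carbon), and the step was a 4.9-fold lower number from compound 1 to compound 2 (0.69 log units; beyond the scatter). For compound 3 the value > 10000 nM is a limit of the assay and not a number, namely (the limit of > 10000 nM in this assay, at which 1 of the 3 values shown sits). The difference between the core of compound 1 and the core of compound 3 is not broken down here.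

Compound 4, `COc1ccc(S(=O)(=O)/C=C/c2ncccc2F)cc1`, is not yet measured in this assay. It differs from compound 3 by fluoro in place of hydrogen on an aromatic carbon, the same change, at the same place, as from compound 1 to compound 2. A step of about an at least 2.0-fold lower number from compound 3 to compound 4 (0.30 log units; that floor lies within the scatter) is expected, resting on the measured step of a 4.9-fold lower number from compound 1 to compound 2 (0.69 log units; beyond the scatter). Since compound 3 sits at a limit, compound 4 is estimated at about 5000 nM, between 1500 nM and 15000 nM, and may itself return only a limit.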

Compound 4, half-maximal effective concentration: 1080 nM
The estimate for compound 4 lay 4.6-fold (0.67 log units) above the measured number, and the stated range ends above it.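

In this assay, fluoro in place of hydrogen on the aromatic carbon again lowers the number on the second core, with an at least 9.2-fold lower number from compound 3 to compound 4 (0.96 log units; beyond the scatter). Compound 3 gives > 10000 nM, which is a limit of the assay and not a number. The direction of the step therefore holds on both cores shown, but two cores make no general rule, and whether the step keeps its size from one core to the other remains unsettled: the same change on two cores in this assay, a 4.9-fold lower number (0.69 log units; beyond the scatter) from compound 1 to compound 2 and an at least 9.2-fold lower number (0.96 log units; beyond the scatter) from compound 3 to compound 4; the limit leaves it open whether they differ

Still open, as far as these compounds go, is whether chloro, methyl or a nitrile at this same place on the ring would give a similar step. Also open, from the compounds shown here alone, is how an amine or a carboxylic acid in place of the methoxy group would read on either core.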